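The source may report more compounds than this note shows. Statements on the series, on what has been measured and on what is new or still open speak of the compounds shown alone.

Compound 1, with the structure `Nc1cc(N)c2nc(-c3ccccc3)c(Oc3ccc(Cl)c(Cl)c3)nc2c1`, was examined in a functional assay on NCI-H226 cells (Homo sapiens) for inhibition, read by sulforhodamine B assay, with a stated time of 48 h (a higher number here means a weaker inhibitor of growth, a lower number a stronger inhibitor of growth), and gave 49000 nM, the higher of the two numbers obtained among its companions. Compound 3 `CCOC(=O)[C@H](CCC(=O)O)NC(=O)c1ccc(Oc2nc3cc(N)cc(N)c3nc2-c2ccccc2)cc1` gave 25100 nM in this assay, a value that differs from that of compound 1 by an amount within the usual scatter, so no order between the two can be stated. Compound 2 `CCOC(=O)[C@H](CCC(=O)O)NC(=O)c1ccc(CNc2nc3cc(N)cc(N)c3nc2-c2ccccc2)cc1` returned only a limit of the assay, < 100000 nM, and not a number, which is the situation described by the limit of < 100000 nM in this assay, at which 1 of the 3 values shown sits.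

Compound 4 `Nc1cc(N)c2nc(-c3ccccc3)c(NCc3ccc(F)cc3)nc2c1` has not yet been measured. It differs from compound 1 in one place: (4-fluorobenzyl)amino in place of 3,4-dichlorophenoxy on an aromatic carbon. For the measured compounds named here, no measured pair tracks this change, so there is no step to lean on. Compound 4 is expected to sit close to compound 1, with a step of a 1.2-fold lower number from compound 1 to compound 4 (0.09 log units; within the scatter) that need not exceed the scatter in either direction. The estimate for compound 4 is 40000 nM, with a range from 10000 nM to 150000 nM.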

Compound 4, concentration for total growth inhibition: 47900 nM
Beside the measured number, compound 4's estimate is 1.2-fold (0.08 log units) below it, and the stated range covers the measured number.
By their numbers in this assay, from the lowest: compounds 3, 4 and 1 (each within the scatter of the next).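

For the compounds shown here, this is the first step between two compounds that differ in one place, and it concerns the aromatic carbon next to the ring nitrogen. Putting (4-fluorobenzyl)amino in place of 3,4-dichlorophenoxy there gives a 1.0-fold lower number from compound 1 to compound 4 (0.01 log units; within the scatter) in this assay, so the two groups cannot be told apart in this read-out, although the entering group brings a hydrogen-bond donor that the leaving group lacks. Nothing measured here offers a reason for this result.

On these data alone, it remains open whether a group of another kind at this position, such as a morpholine or a carboxylic acid on a longer chain, would separate from these two. Also open, as far as these compounds go, is how a 3,4-dichlorobenzylamino group, which would carry the chlorines on the amine-linked ring, would compare with compound 4.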